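The source may hold more compounds than are shown below. What is called first, only, known or untested is meant among the compounds shown, and "the series" means these compounds.

Compound 1 `CCOC(=O)c1oc2ccc(NS(=O)(=O)c3ccccc3Cl)cc2c1C`, compound 2 `CCOC(=O)c1oc2ccc(NS(=O)(=O)c3ccc(Br)cc3)cc2c1C` and compound 3 `CCOC(=O)c1oc2ccc(NS(=O)(=O)c3ccc(C(F)(F)F)cc3)cc2c1C` share one core; compound 4 `CCOC(=O)c1oc2ccc(NS(=O)(=O)c3ccc(C(C)(C)C)cc3)cc2c1C` is not yet measured. In a functional assay on MDA-MB-231 cells (Homo sapiens) for antiproliferative activity, read by MTT assay, with a stated time of 72 h (on this read-out lower numbers stand for stronger inhibition and higher numbers for weaker inhibition), compound 1 gives only a limit, > 200000 nM. In this assay compound 2 gives 31100 nM and compound 3 gives 24300 nM, the lowest of the two numbers, with compound 2 nearest and within the scatter.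

The change to compound 4 is tert-butyl in place of trifluoromethyl on an aromatic carbon. The step of a 1.3-fold lower number from compound 2 to compound 3 (0.11 log units; within the scatter) changed the same position and stayed within the scatter; an at least 6.4-fold lower number from compound 1 to compound 2 (0.80 log units; beyond the scatter) concerned another position and was larger. No step beyond the scatter is therefore expected from compound 3 to compound 4, a 1.0-fold higher number from compound 3 to compound 4 (0.01 log units; within the scatter). Compound 4 is estimated at 25000 nM, between 8000 nM and 80000 nM.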

Compound 4, half-maximal inhibitory concentration: 22400 nM
Compound 4: middle estimate off by 1.1-fold (0.05 log units), on the high side, within the range that was stated.
By their numbers in this assay, from the lowest: compounds 4, 3 and 2 (each within the scatter of the next). At a limit, above all of these: compound 1.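

In this assay, swapping in tert-butyl at the aromatic carbon para to a large group leaves the read-out flat, with a 1.1-fold lower number from compound 3 to compound 4 (0.04 log units; within the scatter) and a 1.4-fold lower number from compound 2 to compound 4 (0.14 log units; within the scatter) as the steps. Across compounds 2, 3 and 4, bromo, trifluoromethyl and tert-butyl are therefore not told apart at this position, and an all-carbon group without fluorine or bromine gives a number within the scatter of both. No measurement shown bears on why these three groups are not told apart. Open, on these data alone, is whether an amine, a carboxylic acid or a longer chain at this position would give a step beyond the scatter.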